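Replacing a Saturated Bicyclic Amine with Tetrahydroquinoline

The compounds below may be only part of what the source reports. "The series", "measured", "known", "first", "only" and "open" are said of these compounds alone.

Compound 3 `COc1ccc2[nH]c(C(=O)N3CC(=O)N(Cc4ccccc4)[C@@H](CN4CC5CC5C4)C3)cc2c1` gives 17500 nM in a physicochemical assay for solubility, read by spectrophotometry, in phosphate buffer, with a stated time of 2 h, at pH 7.4 (a lower number here means a less soluble compound, a higher number a more soluble compound), the second highest of the three numbers measured: compound 1 `COc1ccc2[nH]c(C(=O)N3CC(=O)N(Cc4ccccc4)[C@@H](N4CCc5ccccc54)C3)cc2c1` gives 7000 nM in this assay, and compound 2 `COc1ccc2[nH]c(C(=O)N3CC(=O)N(Cc4ccccc4)[C@@H](CN4CC5(CCC5)C4)C3)cc2c1` gives 60700 nM. Compound 4 `COc1ccc2[nH]c(C(=O)N3CC(=O)N(Cc4ccccc4)[C@@H](CN4CCCc5ccccc54)C3)cc2c1` differs from compound 3 by a group of 10 heavy atoms (9 carbon, 1 nitrogen; one six-membered non-aromatic ring with 1 hetero atom, one six-membered aromatic ring of carbon only) in place of a group of 6 heavy atoms (5 carbon, 1 nitrogen; one three-membered non-aromatic ring of carbon only, one five-membered non-aromatic ring with 1 hetero atom), on a saturated chain carbon bound to a saturated ring carbon. The measured step that bears most on this change ran the other way: a 2.5-fold higher number from compound 1 to compound 3 (0.40 log units; beyond the scatter), as a group holding a six-membered aromatic ring gave way to a saturated one. The steps of an 8.7-fold higher number from compound 1 to compound 2 (0.94 log units; beyond the scatter) and a 3.5-fold lower number from compound 2 to compound 3 (0.54 log units; beyond the scatter) stayed among saturated groups. Because a 2.5-fold higher number from compound 1 to compound 3 (0.40 log units; beyond the scatter) rose when the aromatic ring left, a modest fall is expected now that one returns, a 2.9-fold lower number from compound 3 to compound 4 (0.46 log units; beyond the scatter). Compound 4 is estimated at 6000 nM, within a range from 2000 nM to 18000 nM.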

Compound 4, solubility: 8500 nM
The estimate for compound 4 lay 1.4-fold (0.15 log units) below the measured number; the measured number falls inside the stated range.
By their numbers in this assay, from the lowest: compounds 1 and 4 (each within the scatter of the next); then compound 3; then compound 2.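

In this assay compound 4, with 1,2,3,4-tetrahydroquinolin-1-yl on the saturated chain carbon, stands under both compounds with saturated groups there (a 2.1-fold lower number from compound 3 to compound 4 (0.31 log units; beyond the scatter); a 7.1-fold lower number from compound 2 to compound 4 (0.85 log units; beyond the scatter)). The two compounds whose groups hold a six-membered aromatic ring stay level (a 1.2-fold higher number from compound 1 to compound 4 (0.08 log units; within the scatter)), although their groups differ in ring size and place. Nothing shown explains these differences. On these data alone, what a morpholine or a piperazine would give at this place remains open.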